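The compounds below may be only part of what the source reports. "The series", "measured", "known", "first", "only" and "open" are said of these compounds alone.

Measured so far:

compound 1, `Cc1ccccc1C(=O)Nc1cc(C#N)ccn1`: 2.8 in a physicochemical assay for lipophilicity, read by HPLC, at pH 7.4; a higher number here means a more lipophilic compound, a lower number a more polar compound
compound 2, `COc1ccc(NC(=O)c2ccccc2C)nc1`: 2.5 in this assay

Of the compounds shown here, two have been measured, and both share the same core; they differ only in the group carried on the ring attached to the amide nitrogen. In this assay compound 1 gives 2.8 and compound 2 gives 2.5. These two numbers lie within the usual scatter of one another, so nothing can be read from their difference about which compound is the more lipophilic. Compound 1 is the starting point for the next step.

The compound still to be measured is compound 3, `Cc1ccccc1C(=O)Nc1cc(Cl)ccn1`. It keeps the whole of compound 1 except at one position, where the change is chloro in place of cyano on an aromatic carbon. Going by the values given here, no measured pair in this set shows the effect of exactly this swap, so there is no direct comparison to lean on; the expectation rests on the value of compound 1 alone.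

Starting from compound 1 at 2.8, compound 3 is expected to come out higher in this assay, with a step of about a number 0.80 log units higher from compound 1 to compound 3 (beyond the scatter), which would be beyond the scatter. Compound 3 is therefore estimated at 3.6, within a range from 3.2 to 4.1.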

Compound 3, distribution coefficient: 3.4
For compound 3 the middle estimate is 0.20 log units above the measured one; the measured number falls inside the stated range.
By their numbers in this assay, from the lowest: compounds 2 and 1 (each within the scatter of the next); then compound 3.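

In this assay, going by these compounds alone, placing chloro instead of cyano on the aromatic carbon opposite the ring nitrogen gives a step of a number 0.60 log units higher from compound 1 to compound 3 (beyond the scatter), and this is the first change in the set that can be read as a single swap. It shows that this position is not silent in this assay: one replacement here, with the rest of the molecule unchanged, moves the number by more than repeat measurements would. The swap changes several things at once, since a two-atom group with a triple bond and a hydrogen-bond acceptor gives way to a single chlorine atom with no acceptor, and no supporting measurement separates these differences or explains the step.

Within the data shown here, this is still only one pair, so it remains open whether an amine, a carboxylic acid or a longer carbon chain on the same carbon would raise or lower the number, and by how much. It is also unknown whether chloro in place of cyano would give a step of similar size at another position or on a different core.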